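Phenyl to oxan-4-yl on the sulfonyl sulfur

The source may hold more compounds than are shown below. What is called first, only, known or untested is meant among the compounds shown, and "the series" means these compounds.

Going by the values given here, in an ADME assay on the whole organism (Rattus norvegicus, strain Harlan-Han Wistar) for pharmacokinetics (a lower number here means slower removal, a higher number faster removal of the compound), compound 1 `Cc1ccc2[nH]c(C(=O)N[C@H]3CN(S(=O)(=O)c4ccccc4)C[C@@H]3C(=O)NCCN(C)C)cc2c1` gives 79 mL/min/kg, the higher of the two numbers so far. Compound 2 `Cc1ccc2[nH]c(C(=O)N[C@H]3CN(S(=O)(=O)c4ccnnc4)C[C@@H]3C(=O)NCCN(C)C)cc2c1` gives 34 mL/min/kg. Compound 3 `Cc1ccc2[nH]c(C(=O)N[C@H]3CN(S(=O)(=O)C4CCOCC4)C[C@@H]3C(=O)NCCN(C)C)cc2c1` has oxan-4-yl in place of phenyl on a sulfonyl sulfur. Among the compounds with values here, the one measured step bearing on this is a 2.3-fold lower number from compound 1 to compound 2 (0.37 log units; beyond the scatter), a modest change beyond the scatter, with pyridazin-4-yl in place of phenyl on that sulfur. A single step is thin support, so a similar or somewhat smaller fall in this assay is expected. The expected step is a 1.6-fold lower number from compound 1 to compound 3 (0.22 log units; within the scatter). For compound 3 the estimate is 48 mL/min/kg, with an expected range of 25 mL/min/kg to 85 mL/min/kg.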

Compound 3, clearance: 104 mL/min/kg
For compound 3 the middle estimate is 2.2-fold (0.34 log units) below the measured one; measured number outside the range, above it.
By their numbers in this assay, from the lowest: compound 2; then compounds 1 and 3 (each within the scatter of the next).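

In this assay oxan-4-yl in place of phenyl on the sulfonyl sulfur gives a 1.3-fold higher number from compound 1 to compound 3 (0.12 log units; within the scatter) and so does not share the fall seen with pyridazin-4-yl. Oxan-4-yl in place of pyridazin-4-yl gives a 3.1-fold higher number from compound 2 to compound 3 (0.49 log units; beyond the scatter) and shows that a hetero atom in a six-membered ring does not by itself bring the number down at this position. Nothing available explains the gap between these two groups.

Going by these compounds, whether the lower number of compound 2 goes with its aromatic ring or with its ring nitrogens remains open. In this assay a pyridin-4-yl group or a piperidin-4-yl amine on the same sulfur would help separate the two.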